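Compound 4: A Ring Exchange Starting From Compound 1

This account rests on a few compounds, and the source may have more. Where it says the series, first, only, none or still open, it means among the compounds named here.

Three compounds were measured in an ADME assay on cells (Hepatocyte, Rattus norvegicus) for metabolic stability; on this read-out lower numbers stand for slow clearance and higher numbers for fast clearance:
compound 1, `COc1cc(F)ccc1-c1ccnc2[nH]c(C3CCN(CC(=O)N(C)C)CC3)cc12`, 38 uL/min
compound 2, `COc1cc(F)ccc1-c1ccnc2[nH]c(C3CCN(C(C)=O)CC3)cc12`, 50 uL/min
compound 3, `COc1cc(F)ccc1-c1ccnc2[nH]c(C3CCOCC3)cc12`, 97 uL/min

Compound 1 stands lowest of the three; its nearest neighbour is compound 2 (a 1.3-fold higher number from compound 1 to compound 2 (0.12 log units; within the scatter)), and compound 3 is furthest, the step of a 1.9-fold higher number from compound 2 to compound 3 (0.29 log units; within the scatter) adding to that. Compound 4, `CN(C)C(=O)CN1CCC(c2cc3c(-c4ccc(=O)n(C)c4)ccnc3[nH]2)CC1`, differs from compound 1 on the shared core: a group of 8 heavy atoms (6 carbon, 1 nitrogen, 1 oxygen; one six-membered aromatic ring with 1 hetero atom) in place of a group of 9 heavy atoms (7 carbon, 1 oxygen, 1 fluorine; one six-membered aromatic ring of carbon only), on an aromatic carbon. Among the measured compounds shown here, neither measured step touches this part of the molecule, so no measured step bears on it directly. Without such precedent, a step no larger than the scatter is expected in this assay, a 1.2-fold lower number from compound 1 to compound 4 (0.07 log units; within the scatter). Compound 4 is therefore estimated at 32 uL/min, with a range from 12 uL/min to 85 uL/min.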

Compound 4, intrinsic clearance in a liver preparation (reported as CLH), per the amount of preparation that the assay uses in the Hepatocyte assay: < 1 uL/min
Compound 4 ended at the assay's limit (the forecaster's own chance of this, stated with the estimate: 5%); middle value at least 32-fold (1.50 log units) from the limit.
By their numbers in the Hepatocyte assay, from the lowest: compounds 1, 2 and 3 (each within the scatter of the next, the first and the last beyond it). At a limit, below all of these: compound 4.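

Only the aromatic carbon opposite the ring nitrogen changes here, yet in the Hepatocyte assay the exchange of 4-fluoro-2-methoxyphenyl for the new group gives an at least 38-fold lower number from compound 1 to compound 4 (1.57 log units; beyond the scatter), so this position, untouched by both earlier steps, has a large bearing on the read-out. In a physicochemical assay for solubility, in phosphate buffer, at pH 7.4 (a lower number here means a less soluble compound, a higher number a more soluble compound), compound 1 gives 38000 nM. In the physicochemical assay compound 4 gives > 1000000 nM, a limit of the assay, and its value in the Hepatocyte assay is a limit too.

The compounds shown leave open how an amine or a carboxylic acid at this aromatic carbon would read. They also leave open whether the step holds with acetyl or oxan-4-yl at the other end of the molecule.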